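A single stereocentre change in a polyhydroxylated ring acid

The source may hold more compounds than are shown below. What is called first, only, known or untested is meant among the compounds shown, and "the series" means these compounds.

Measured compounds:
compound 1 `O=C(O)[C@@H]1NC[C@@H](O)[C@@H](O)[C@@H]1O`: 7.2%
compound 2 `O=C(O)[C@@H]1NC[C@@H](O)[C@H](O)[C@H]1O`: 1.3%

Compound 2 stands lowest of the two numbers in an assay for inhibition of alpha-N-acetylgalactosaminidase (Gallus gallus), tested at 1000 uM (a lower number here means less inhibition, a higher number more inhibition at the concentration tested (going by the name of the read-out)), with compound 1 nearest and the gap between them within the scatter. Going by the values given here, the one measured step, a number 5.9 percentage points lower from compound 1 to compound 2 (within the scatter), rests on the fact that compounds 1 and 2 differ only in the configuration as drawn and moved the number little. Compound 3 `O=C(O)[C@@H]1NC[C@@H](O)[C@H](O)[C@@H]1O` differs from compound 2 as follows: the two compounds have the same atoms and bonds and differ only in configuration as drawn: 1 of 4 stereo elements differ; a stereocentre at a saturated ring carbon is drawn S in compound 2 and R in compound 3. Since both measured compounds sit near the bottom of the scale, no step beyond the scatter is expected, a number 3.7 percentage points higher from compound 2 to compound 3 (within the scatter). Compound 3 is therefore estimated at 5%, within a range from 0% to 20%.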

Compound 3, a percentage reported as inhibition, at one concentration (the size of the read-out at that concentration, not a potency): 10%
Estimate against measurement, compound 3: 5 percentage points below; low and high end bracket the measured number.
By their numbers in this assay, from the lowest: compounds 2, 1 and 3 (each within the scatter of the next).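

Changing a single stereocentre, at either of two ring carbons, gave a number 8.7 percentage points higher from compound 2 to compound 3 (within the scatter) and a number 2.8 percentage points higher from compound 1 to compound 3 (within the scatter). In this assay, neither single change therefore separates the compounds, and no one of these configurations can be singled out at the concentration tested. The comparison rests on stereochemistry alone: the fact that compounds 2 and 3 differ only in the configuration as drawn

All three compounds keep the carboxylic acid and the same hydroxyl groups, so the shared core leaves open what an ester in place of the acid would do. It also leaves open what a longer chain on the ring amine would do.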